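Removing the octylcarbonyl from the ring nitrogen of compound 2

The source may hold more compounds than are shown below. What is called first, only, known or untested is meant among the compounds shown, and "the series" means these compounds.

Of the compounds shown here, two have been measured in a functional assay on MDA-MB-231 cells (Homo sapiens) for cytotoxicity, read by sulforhodamine B assay, with a stated time of 72 h; on this read-out higher numbers stand for weaker inhibition of growth and lower numbers for stronger inhibition of growth. Compound 1 `O=C(Nc1ccccc1C(F)(F)F)C1CCc2ccccc2N1` carries a free ring nitrogen and a trifluoromethyl on the anilide; in this assay compound 1 gives 45500 nM. Compound 2 `CCCCCCCCC(=O)N1c2ccccc2CCC1C(=O)Nc1ccccc1O` carries an octylcarbonyl on the ring nitrogen and a hydroxy on the anilide; in this assay compound 2 gives 54300 nM. The two numbers lie within the usual scatter of each other, so neither compound is set apart, and both sit at weak growth inhibition.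

Compound 3 `O=C(Nc1ccccc1O)C1CCc2ccccc2N1` is the unmeasured partner of compound 2: the change is hydrogen in place of octylcarbonyl on a nitrogen on an aromatic ring in a ring. For the measured compounds named here, no measured pair shows this step on its own. Since compound 1, which also has a free ring nitrogen, and compound 2 do not differ beyond the scatter, no shift beyond the scatter is expected in either direction for compound 3. The step from compound 2 to compound 3 is therefore estimated as a 1.1-fold lower number from compound 2 to compound 3 (0.04 log units; within the scatter). In this assay compound 3 is expected to give 50000 nM, within a range of 15000 nM to 150000 nM.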

Compound 3, concentration for 50% growth inhibition: 5260 nM
Compound 3: the middle estimate sits 9.5-fold (0.98 log units) above what was measured, outside the stated range (below it).
By their numbers in this assay, from the lowest: compound 3; then compounds 1 and 2 (each within the scatter of the next).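

In this assay hydrogen in place of octylcarbonyl on the nitrogen on an aromatic ring gives a 10-fold lower number from compound 2 to compound 3 (1.01 log units; beyond the scatter) and so shows that, with a hydroxy on the anilide, this position responds, the free ring nitrogen going with the stronger inhibition of growth. The anilide position responds as well: with the ring nitrogen free, hydroxy in place of trifluoromethyl on an aromatic carbon gives an 8.7-fold lower number from compound 1 to compound 3 (0.94 log units; beyond the scatter) and sets compound 3 apart from this neighbour too. The earlier pair differ in two places at once and could show neither step alone, whereas compound 3 differs from each of them in one place and lies beyond the scatter of both.

Still open, on these data alone, is whether a shorter acyl chain such as acetyl on the ring nitrogen keeps any of this gain, whether the same step holds with trifluoromethyl on the anilide, and whether an amine or a carboxylic acid there would match hydroxy. No evidence is at hand on what lies behind either step.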